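The compounds below may be only part of what the source reports. "The series", "measured", "known", "first", "only" and "open" are said of these compounds alone.

Measured compounds in a functional assay on MCF7 cells (Homo sapiens) for antiproliferative activity, read by MTT assay, with a stated time of 24 h; a higher number here means a weaker inhibitor, a lower number a stronger inhibitor:
- compound 1 `CCn1c(C(=O)NCCNC(=O)OC(C)(C)C)ccc1C(CC)(CC)c1ccc(OCS(=O)(=O)c2ccccc2)c(C)c1`: > 50000 nM (a limit of the assay, not a number)
- compound 2 `CCn1c(C(=O)N[C@@H](CO)C(C)C)ccc1C(CC)(CC)c1ccc(OCS(=O)(=O)c2ccccc2)c(C)c1`: 18800 nM

For the measured compounds named here, compound 2 holds the only numerical value shown in this assay; the other value shown is a limit. Going by the values given here, the one measured step, an at least 2.6-fold lower number from compound 1 to compound 2 (0.42 log units; beyond the scatter), is the exchange at the amide-type nitrogen; its size is bounded by the limit of > 50000 nM in this assay, at which 1 of the 2 values shown sits, where compound 1 sits, so only its lower bound is known.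

The unmeasured compound 3 `CCn1c(C(=O)N[C@H](C(=O)O)C(C)C)ccc1C(CC)(CC)c1ccc(OCS(=O)(=O)c2ccccc2)c(C)c1` differs from compound 2 by 1-carboxy-2-methylpropyl in place of 1-(hydroxymethyl)-2-methylpropyl on an amide-type nitrogen. Among the compounds with values here, no measured step bears on this exchange: the step from compound 1 to compound 2 concerns a different pair of side chains at the same nitrogen and says nothing about hydroxymethyl against carboxy. Compound 2 itself is weak in this assay, so the expectation for compound 3 rests on it alone, with a wide range and a real chance that this assay again returns only a limit. Compound 3 is expected to give about 25000 nM in this assay, within 8000 nM to 80000 nM. This estimate means a step of a 1.3-fold higher number from compound 2 to compound 3 (0.12 log units; within the scatter), which is not expected to reach beyond the scatter in either direction.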

Compound 3, half-maximal inhibitory concentration: 24500 nM
Compound 3: the middle estimate sits 1.0-fold (0.01 log units) above what was measured; the measured number falls inside the stated range.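

At the amide-type nitrogen in this assay, exchanging 1-(hydroxymethyl)-2-methylpropyl for 1-carboxy-2-methylpropyl gives a 1.3-fold higher number from compound 2 to compound 3 (0.12 log units; within the scatter), so these two side chains cannot be told apart here. Exchanging 2-((tert-butoxycarbonyl)amino)ethyl for 1-carboxy-2-methylpropyl gives an at least 2.0-fold lower number from compound 1 to compound 3 (0.30 log units; that floor lies within the scatter), so, unlike the earlier step to compound 2, this step is not shown to exceed the scatter. The value of compound 1 is a limit and not a number, which leaves this step with a floor only: the limit of > 50000 nM in this assay, at which 1 of the 3 values shown sits.

Compound 2 and compound 3 share the 2-methylpropyl branch and differ only at its hydroxymethyl or carboxy end, so the series shows little of what this position tolerates beyond those two ends. Open, from the compounds shown here alone, is whether an amine or a primary amide in place of the carboxylic acid, or a longer chain between the amide-type nitrogen and the carboxylic acid, would move the number in this assay beyond the scatter from compound 2 and compound 3.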